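Methoxy removal on the ketone arm of the chalcone pyrazoles

The compounds below may be only part of what the source reports. "The series", "measured", "known", "first", "only" and "open" are said of these compounds alone.

In a functional assay on SR cells (Homo sapiens) for cytotoxicity, read by sulforhodamine B assay, with a stated time of 48 h, tested at 0.01 uM (on this read-out higher numbers stand for a weaker effect at the one concentration tested and lower numbers for a stronger effect), compound 2 `COc1ccc(C(=O)/C=C/c2cc(-c3cc(OC)c(OC)c(OC)c3)n[nH]2)cc1OC` gives 100% and compound 1 `COc1cc(-c2cc(/C=C/C(=O)c3ccc(N)cc3)[nH]n2)cc(OC)c1OC` gives 92%; the step of a number 8 percentage points higher from compound 1 to compound 2 (within the scatter) lies within the scatter, so the two stand level and compound 2 holds the larger of two numbers that do not separate. Compound 3 `COc1ccc(C(=O)/C=C/c2cc(-c3cc(OC)c(OC)c(OC)c3)n[nH]2)cc1` differs from compound 2 by hydrogen in place of methoxy on an aromatic carbon. For the measured compounds named here, the one measured step bears on this change only loosely, as it swapped the whole group on the carbonyl carbon, and because a number 8 percentage points higher from compound 1 to compound 2 (within the scatter) stayed within the scatter no step beyond the scatter is expected here, a number 2 percentage points lower from compound 2 to compound 3 (within the scatter). Compound 3 is estimated at 98%, between 86% and 110%.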

Compound 3, a percentage reported as activity, at one concentration (the size of the read-out at that concentration, not a potency): 97%
Beside the measured number, compound 3's estimate is 1 percentage points above it; measured number inside the range.
By their numbers in this assay, from the lowest: compounds 1, 3 and 2 (each within the scatter of the next).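

Cutting 3,4-dimethoxyphenyl back to 4-methoxyphenyl gives a number 3 percentage points lower from compound 2 to compound 3 (within the scatter) in this assay, so this methoxy can go without the read-out separating from that of compound 2. Methoxy in place of amino on an aromatic carbon gives a number 5 percentage points higher from compound 1 to compound 3 (within the scatter), which leaves these two groups level as well. Nothing measured accounts for this flat result.

Going by these compounds, whether a carboxylic acid or a fluorine on this ring would separate from these three compounds stays open. So does whether these steps would stay within the scatter at a higher concentration.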